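Swapping the carbamoyl for a sulfonyl in compound 2

The compounds below may be only part of what the source reports. "The series", "measured", "known", "first", "only" and "open" are said of these compounds alone.

Measured so far in a functional assay on DU-145 cells (Homo sapiens) for inhibition, read by trypan blue exclusion, with a stated time of 72 h; a higher number here means a weaker inhibitor, a lower number a stronger inhibitor
- compound 1 `Cn1c(=O)c(S(=O)(=O)c2ccc(Cl)cc2Cl)cc2cnc(Nc3ccc4[nH]ccc4c3)nc21` gives 1000 nM
- compound 2 `Cn1c(=O)c(C(=O)Nc2ccc(F)cc2)cc2cnc(Nc3ccc4[nH]ccc4c3)nc21` gives 5000 nM
- compound 3 `Cc1ccc(S(=O)(=O)c2cc3cnc(Nc4cnc5c(c4)CC(=O)N5)nc3n(C)c2=O)cc1` gives 15000 nM

Compound 2 (5000 nM) stands second highest of the three numbers, with compound 1 lower and compound 3 higher, both gaps beyond the scatter. The next step leads to compound 4 `Cn1c(=O)c(S(=O)(=O)c2ccc(Br)cc2)cc2cnc(Nc3ccc4[nH]ccc4c3)nc21`, in which (4-bromophenyl)sulfonyl replaces (4-fluorophenyl)carbamoyl on an aromatic carbon ((4-bromophenyl)sulfonyl in place of (4-fluorophenyl)carbamoyl on an aromatic carbon). Going by the values given here, one measured step bears directly on this change, and it is modest (a 5.0-fold higher number from compound 1 to compound 2 (0.70 log units; beyond the scatter)). There, (4-fluorophenyl)carbamoyl came in place of (2,4-dichlorophenyl)sulfonyl, so the present change runs the opposite way, though the two sulfonyl groups are not the same. Compound 3 (15000 nM) also carries a sulfonyl group but differs from compound 4 in more than one place, and it goes against any simple rule that sulfonyl compounds give low numbers. A lower number in this assay is therefore expected, of roughly the size of the measured step, with a wide margin. The estimated change is a 4.2-fold lower number from compound 2 to compound 4 (0.62 log units; beyond the scatter) (an expectation only). The estimated value for compound 4 is 1200 nM (expected range 350 nM to 4000 nM).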

Compound 4, half-maximal inhibitory concentration: 5000 nM
Estimate against measurement, compound 4: 4.2-fold (0.62 log units) below; the measured number lies above the stated range.
By their numbers in this assay, from the lowest: compound 1; then compounds 2 and 4 (each within the scatter of the next); then compound 3.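

At this aromatic carbon, (4-bromophenyl)sulfonyl in place of (4-fluorophenyl)carbamoyl gives no change at the digits printed from compound 2 to compound 4 (within the scatter) in this assay, so among these compounds a sulfonyl in this place does not by itself bring a lower number. The difference appears within the sulfonyl pair instead: 4-bromophenyl in place of 2,4-dichlorophenyl on the sulfonyl sulfur gives a 5.0-fold higher number from compound 1 to compound 4 (0.70 log units; beyond the scatter), the same size as a 5.0-fold higher number from compound 1 to compound 2 (0.70 log units; beyond the scatter). Compound 1 therefore stands apart from compound 2 and compound 4 through its 2,4-dichlorophenyl group rather than through the sulfonyl alone, though this rests on a single pair of sulfonyl compounds. Nothing available explains either step.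

On these data alone, the 2,4-dichlorophenyl and 4-bromophenyl groups differ in more than one feature, so it remains open whether a 4-chlorophenyl group on the same sulfonyl would read with compound 1 or with compound 4. Also open, as far as these compounds go, is how an amine or a carboxylic acid on that phenyl ring would move the number in this assay, and whether the same reading holds on the core of compound 3.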